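Compound 2 and a hydroxy-dimethylphenyl swap

A few compounds are considered here, and "the series" means these few. Any claim that something is new, unique, unknown or untested is made for them only; others in the source may bear on it.

Compound 1 `CCC1=C(O)c2c(oc(-c3cccc(F)c3)cc2=O)C(CC)(CC)C1=O` gives 3.09 uM
Compound 2 `CCC1=C(O)c2c(oc(-c3ccc(OC)c(Cl)c3)cc2=O)C(CC)(CC)C1=O` gives 1.37 uM

In a functional assay on KBVIN cells (Homo sapiens) for antiproliferative activity, read by sulforhodamine B assay, with a stated time of 3 days (a lower number here means that less compound is needed, a higher number that more compound is needed for the effect), compound 2 stands lowest of the two measured compounds at 1.37 uM, and compound 1 gives 3.09 uM. Compound 3 `CCC1=C(O)c2c(oc(-c3cc(C)c(O)c(C)c3)cc2=O)C(CC)(CC)C1=O` keeps the shared core and carries 4-hydroxy-3,5-dimethylphenyl in place of 3-chloro-4-methoxyphenyl on an aromatic carbon. Among the measured compounds shown here, only one measured step bears on this place, and it is modest: a 2.3-fold lower number from compound 1 to compound 2 (0.35 log units; beyond the scatter) in this assay. That step brought in the very group that now leaves, and it shows that exchanging the aryl group at this place moved the number only modestly. Neither measured compound carries 4-hydroxy-3,5-dimethylphenyl, so the data give no direct reading of it. A step of similar or smaller size is therefore expected, most likely toward a higher number and not clearly beyond the scatter. The estimated step is a 1.8-fold higher number from compound 2 to compound 3 (0.24 log units; within the scatter) in this assay. The estimate for compound 3 is 2.4 uM, with an expected range from 0.9 uM to 6 uM.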

Compound 3, concentration for half-maximal effect: 8.9 uM
Beside the measured number, compound 3's estimate is 3.7-fold (0.57 log units) below it; measured number above the stated range.
By their numbers in this assay, from the lowest: compound 2; then compound 1; then compound 3.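

In this assay this aryl place on the shared core proves more sensitive than the earlier pair showed: 4-hydroxy-3,5-dimethylphenyl in place of 3-chloro-4-methoxyphenyl gives a 6.5-fold higher number from compound 2 to compound 3 (0.81 log units; beyond the scatter) and is a clearly larger move than the one first seen here. Among the compounds shown here, the new group also falls behind 3-fluorophenyl, with a 2.9-fold higher number from compound 1 to compound 3 (0.46 log units; beyond the scatter) as the step, so all three aryl groups now stand apart from one another beyond the scatter, and the only one bearing a hydroxy group sits at the high end, although a single compound makes no pattern. Nothing available here accounts for this rise.

The exchange also leaves unresolved which part of it matters, since the hydroxy and the two methyl groups enter together while the chlorine and the methoxy leave together. As far as these compounds go, how a phenyl ring carrying the hydroxy alone, an amine or a carboxylic acid at this place would read in this assay remains open.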